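Changing the aryl group on the ketone of a thiazole amide

A few compounds are considered here, and "the series" means these few. Any claim that something is new, unique, unknown or untested is made for them only; others in the source may bear on it.

Compound 1 `Cc1ccc(C(=O)c2ccc(OCC(=O)Nc3nc(-c4ccccc4)cs3)c(C)c2)cc1`: 25000 nM
Compound 2 `Cc1cc(C(=O)c2cccc(Br)c2)ccc1OCC(=O)Nc1nc(-c2ccccc2)cs1`: 21700 nM

Both compounds share one core and were tested in a functional assay on DLA cells (Mus musculus) for cytotoxicity, read by trypan blue exclusion, with a stated time of 48 h; on this read-out higher numbers stand for weaker inhibition and lower numbers for stronger inhibition. Going by the values given here, on the two numbers so far, compound 2 gives 21700 nM, the lowest of them, and its nearest neighbour is compound 1, which gives 25000 nM; the two sit within the scatter of each other, so neither can be called stronger or weaker. Among the compounds with values here, the only measured step is a 1.2-fold lower number from compound 1 to compound 2 (0.06 log units; within the scatter), a change of the ring attached to the carbonyl carbon that left the read-out essentially unmoved.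

Compound 3 `Cc1cc(C(=O)c2ccccc2C)ccc1OCC(=O)Nc1nc(-c2ccccc2)cs1` is not yet measured. It differs from compound 2 in the same place: 2-methylphenyl in place of 3-bromophenyl on a carbonyl carbon. Within the data shown here, the one step that bears on this change, from compound 1 to compound 2, altered the same carbonyl-attached ring and stayed within the scatter. A further swap of that ring is therefore expected to give no step beyond the scatter, that is a 1.1-fold higher number from compound 2 to compound 3 (0.03 log units; within the scatter). For compound 3 the expected value is 23000 nM, estimated to lie between 11000 nM and 48000 nM.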

Compound 3, half-maximal inhibitory concentration: 22200 nM
The estimate for compound 3 lay 1.0-fold (0.02 log units) above the measured number; the measured number falls inside the stated range.
By their numbers in this assay, from the lowest: compounds 2, 3 and 1 (each within the scatter of the next).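

In this assay, the third aryl group on the carbonyl carbon gives a 1.0-fold higher number from compound 2 to compound 3 (0.01 log units; within the scatter) and a 1.1-fold lower number from compound 1 to compound 3 (0.05 log units; within the scatter) as well, so all three compounds now sit within the scatter of one another. Going by these compounds alone, the earlier pair showed only that one swap of this ring left the read-out unmoved; the new steps add that 2-methylphenyl cannot be told apart from either 3-bromophenyl or 4-methylphenyl at this place, so neither replacing the bromine-bearing ring nor using a differently named methylphenyl ring separates these compounds. No measurement offered here explains this flat result, which therefore stands as an observation without a cause.

All three groups are single aromatic rings of carbon, and the 3-bromophenyl and 2-methylphenyl groups also match in their counts of heavy atoms, so the compounds shown leave open whether a ring carrying an amine or a carboxylic acid, or a longer chain in place of the ring, would give a number beyond the scatter. They also leave open how the read-out responds to changes elsewhere on the shared core, which stays the same throughout.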